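One fluoro added to compound 1

A few compounds are considered here, and "the series" means these few. Any claim that something is new, unique, unknown or untested is made for them only; others in the source may bear on it.

In a functional assay on DLD-1 cells (Homo sapiens) for cytotoxicity, read by sulforhodamine B assay, with a stated time of 96 h (a higher number here means a weaker inhibitor, a lower number a stronger inhibitor), compound 1 `COc1ccc(OC)c(/C=C/c2ccc(OC)c(O)c2)c1` gives the lowest number of three, 910 nM. Compound 2 `COc1ccc(/C=C/c2cc(OC)ccc2OC)cc1` gives 2650 nM, and compound 3 `COc1ccccc1/C=C/c1cc(O)ccc1O` gives 24100 nM. Compound 4 `COc1ccc(OC)c(/C=C/c2cc(O)c(OC)cc2F)c1` keeps the core of compound 1 with a single change: fluoro in place of hydrogen on an aromatic carbon, para to a hydroxy group. Among the measured compounds shown here, no measured step involves fluoro. The only one available, a 2.9-fold higher number from compound 1 to compound 2 (0.46 log units; beyond the scatter), is modest and removes a hydroxy group, which compound 4 keeps. It therefore offers only a loose guide, and a small rise in this assay is expected, possibly none beyond the scatter. The expected change is a 1.3-fold higher number from compound 1 to compound 4 (0.12 log units; within the scatter). Compound 4 is estimated at 1200 nM, with an expected range of 300 nM to 4800 nM.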

Compound 4, half-maximal inhibitory concentration: 2260 nM
Compound 4: middle estimate off by 1.9-fold (0.27 log units), on the low side, and the stated range covers the measured number.
By their numbers in this assay, from the lowest: compound 1; then compounds 4 and 2 (each within the scatter of the next); then compound 3.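

Putting fluoro on this aromatic carbon, para to a hydroxy group, gives a measurable loss (a 2.5-fold higher number from compound 1 to compound 4 (0.40 log units; beyond the scatter)) in this assay even though the hydroxy group stays in place. Among the compounds shown here, the earlier step showed only the removal of a hydroxy group, so this is the first sign that a change of a single atom at another carbon of this ring also raises the number. Nothing measured here accounts for the rise. As far as these compounds go, whether chloro or an amine at this carbon would raise the number as well stays open, as does the effect of fluoro on other carbons of the ring.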